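Two Hydrazones and a Dimethoxy Swap

The source may hold more compounds than are shown below. What is called first, only, known or untested is meant among the compounds shown, and "the series" means these compounds.

Compound 1 `O=C(Cc1csc2nc(-c3ccc(Br)cc3)cn12)N/N=C/c1ccccc1O`: 4680 nM
Compound 2 `O=C(Cc1csc2nc(-c3ccc(Br)cc3)cn12)N/N=C/c1ccc(O)cc1`: 26300 nM

In a functional assay (786-0 cells, Homo sapiens) for inhibition, read by sulforhodamine B assay, with a stated time of 48 h (a lower number here means a stronger inhibitor of growth, a higher number a weaker inhibitor of growth), compound 2 gives 26300 nM, the higher of the two numbers, which makes it the weaker growth inhibitor of this pair. The next compound, compound 3 `COc1cccc(OC)c1/C=N/NC(=O)Cc1csc2nc(-c3ccc(Br)cc3)cn12`, keeps the shared core and changes only the aromatic ring: 2,6-dimethoxyphenyl in place of 4-hydroxyphenyl on a carbon with a double bond to nitrogen, (2,6-dimethoxyphenyl in place of 4-hydroxyphenyl on a carbon with a double bond to nitrogen).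

For the measured compounds named here, only one measured step bears on this change. It is a 5.6-fold higher number from compound 1 to compound 2 (0.75 log units; beyond the scatter), made at the same place, where 4-hydroxyphenyl replaced 2-hydroxyphenyl. Going by the values given here, that step shows that changes at this place can move the number beyond the scatter, but no measured compound carries a methoxy group. With compound 2 at the top of this small range, a moderate move toward a lower number seems the likelier outcome, though the evidence is thin. The expected change is a 2.4-fold lower number from compound 2 to compound 3 (0.38 log units; beyond the scatter). Compound 3 is estimated at 11000 nM, with an expected range of 3500 nM to 35000 nM.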

Compound 3, concentration for 50% growth inhibition: 26300 nM
The estimate for compound 3 lay 2.4-fold (0.38 log units) below the measured number; the range from low to high includes it.
By their numbers in this assay, from the lowest: compound 1; then compounds 2 and 3 (each within the scatter of the next).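

In this assay, the step to the 2,6-dimethoxyphenyl group gives no change at the digits printed from compound 2 to compound 3 (within the scatter), so this larger group, with 10 heavy atoms against 7 and 0 hydrogen-bond donors against 1, leaves the number where the 4-hydroxyphenyl group had it. The other new step gives a 5.6-fold higher number from compound 1 to compound 3 (0.75 log units; beyond the scatter), which has the same size as a 5.6-fold higher number from compound 1 to compound 2 (0.75 log units; beyond the scatter), so two quite different rings now sit apart from the 2-hydroxyphenyl group, and compound 1 remains the strongest growth inhibitor of the three. The change at this position therefore does not always move the number, and among these compounds only compound 1 stands apart, though no measurement shown explains this.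

From the compounds shown here alone, what remains open is whether the lower number of compound 1 depends on the hydroxy group itself or would also appear with other groups on the ring, such as in 2-aminophenyl or 2-methoxyphenyl. A carboxylic acid in that ring, or a longer chain there, would show how much this position tolerates, and three compounds in one cell line cannot settle that.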